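The source may report more compounds than this note shows. Statements on the series, on what has been measured and on what is new or still open speak of the compounds shown alone.

Compound 1 `CCCCc1nc(C)c(CC(=O)N(CC)CC)c(=O)n1Cc1ccc(-c2ccccc2-c2nnn[nH]2)cc1`: 0.089 mg/kg
Compound 2 `CCCc1nc(C)c(CC(=O)N(CC)CC)c(=O)n1Cc1ccc(-c2ccccc2-c2nnn[nH]2)cc1`: "not determined" (no result reported)
Compound 3 `CCCCc1nc(C)c(CC(=O)N2CCSCC2)c(=O)n1Cc1ccc(-c2ccccc2-c2nnn[nH]2)cc1`: 0.038 mg/kg

These results come from an in vivo functional assay on the whole organism for inhibition, with Rattus norvegicus as the target; a higher number here means that more compound is needed for the effect, a lower number that less compound is needed. Only two of the entries are actual numbers, and compound 1 holds the higher one, at 0.089 mg/kg. Compound 2 therefore offers no comparison.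

Compound 4 `CCCCc1nc(C)c(CC(=O)N2CCOCC2)c(=O)n1Cc1ccc(-c2ccccc2-c2nnn[nH]2)cc1` has not yet been measured. It keeps the core of compound 1 and changes one group on a carbonyl carbon: morpholin-4-yl in place of diethylamino on a carbonyl carbon. For the measured compounds named here, the only measured step that bears on this change is the replacement of diethylamino by thiomorpholin-4-yl at the same place, a 2.3-fold lower number from compound 1 to compound 3 (0.37 log units; beyond the scatter). That step is modest but beyond the scatter. Going by the values given here, no measured compound carries morpholin-4-yl, so this single step is only a rough guide. A similar modest drop is expected, and the estimated step is a 1.6-fold lower number from compound 1 to compound 4 (0.21 log units; within the scatter). For compound 4, the estimated value is 0.055 mg/kg, with an expected range from 0.02 mg/kg to 0.15 mg/kg.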

Compound 4, dose for half-maximal effect: 0.018 mg/kg
Compound 4: the middle estimate sits 3.1-fold (0.49 log units) above what was measured; measured number below the stated range.
By their numbers in this assay, from the lowest: compound 4; then compound 3; then compound 1.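

Replacing diethylamino with morpholin-4-yl on the carbonyl carbon gives a 4.9-fold lower number from compound 1 to compound 4 (0.69 log units; beyond the scatter) in this assay, so among these three compounds, both six-membered rings need less compound than the open diethylamino group. The two rings also differ from each other: with oxygen in the ring in place of sulfur, the result is a 2.1-fold lower number from compound 3 to compound 4 (0.32 log units; beyond the scatter), so the ring's second hetero atom matters here, not just the presence of a ring. Nothing available explains why morpholin-4-yl gives the lowest number of the three.

As far as these compounds go, whether piperidin-1-yl, whose ring has no second hetero atom, or piperazin-1-yl, with a second nitrogen, would match morpholin-4-yl at this place remains open. From the compounds shown here alone, the role of the butyl chain is also open, as compound 2, with its propyl chain, has no reported result.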